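Swapping nitro for fluoro: what happens to cytotoxicity?

A few compounds are considered here, and "the series" means these few. Any claim that something is new, unique, unknown or untested is made for them only; others in the source may bear on it.

Compound 1 (`COc1cc2nc(SCC(=O)Nc3ccc(Cl)cc3)nc(Nc3c(Cl)cc(/C=C/C#N)cc3Cl)c2cc1OC`): 29500 nM
Compound 2 (`COc1cc2nc([S+]([O-])CC(=O)Nc3cccc([N+](=O)[O-])c3)nc(Nc3c(Cl)cc(/C=C/C#N)cc3Cl)c2cc1OC`): >= 83200 nM

These numbers come from an ADME assay on MT4 cells (Homo sapiens) for cytotoxicity, read by MTT assay, with a stated time of 5 days (on this read-out higher numbers stand for lower toxicity in this test and lower numbers for higher toxicity in this test), and the two compounds differ in more than one place. Compound 2 has no exact number, only a limit of >= 83200 nM in this read-out.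

Compound 3 (`COc1cc2nc([S+]([O-])CC(=O)Nc3cccc(F)c3)nc(Nc3c(Cl)cc(/C=C/C#N)cc3Cl)c2cc1OC`) changes one place of compound 2 (fluoro in place of nitro on an aromatic carbon), with fluoro in place of nitro on an aromatic carbon. Going by the values given here, no measured step shows what this swap does in this assay and the expectation is therefore loose. Compound 1 gives an actual number (29500 nM), so compound 3 is expected to give a number too. Compound 3 may also stop at a limit. The expected size (an at least 1.2-fold lower number from compound 2 to compound 3 (0.10 log units; that floor lies within the scatter)) is modest, towards lower numbers and so somewhat higher toxicity. Compound 3 is estimated at 65000 nM (expected range 25000 nM to 120000 nM).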

Compound 3, half-maximal cytotoxic concentration: 9550 nM
For compound 3 the middle estimate is 6.8-fold (0.83 log units) above the measured one; measured number outside the range, below it.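

Going by these compounds alone, this is the first comparison here in which only one place changes: going from 3-nitrophenyl to 3-fluorophenyl, with the rest of the molecule the same, gives an at least 8.7-fold lower number from compound 2 to compound 3 (0.94 log units; beyond the scatter) in this assay. So this single position on the aromatic ring matters for the read-out, and the swap alone is enough to move it towards higher toxicity in this test. Compound 2 has a limit rather than an exact number, so the true size of the step remains unknown: the limit of >= 83200 nM in this assay, at which 1 of the 3 values shown sits.

With only nitro and fluoro to compare, the result cannot show whether the shift follows from adding fluoro or from removing nitro, and a compound with an amine or a carboxylic acid at this place could help separate the two. From the compounds shown here alone, whether the same swap would act alike on the other parts of the series also remains open.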